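Sulfonylpiperazine Analogues of a Shared Xanthine-Type Core

A few compounds are considered here, and "the series" means these few. Any claim that something is new, unique, unknown or untested is made for them only; others in the source may bear on it.

Compounds measured in an assay on CHO cells for displacement of a labelled ligand from adenosine receptor A3 (Homo sapiens), read by scintillation counting, with a stated time of 45 min, in the presence of a further agent that is not named here; a higher number here means a weaker inhibitor, a lower number a stronger inhibitor:
Compound 1 `CCCn1c(=O)c2[nH]c(-c3ccc(S(=O)(=O)N4CCN(c5ccc(Cl)cc5)CC4)cc3)nc2n(CC)c1=O`: > 1000 nM, a limit of the assay.
Compound 2 `CCCn1c(=O)[nH]c2nc(-c3ccc(S(=O)(=O)N4CCN(c5ccc(Br)cc5)CC4)cc3)[nH]c2c1=O`: > 1000 nM, a limit of the assay.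
Compound 3 `CCCn1c(=O)[nH]c2nc(-c3ccc(S(=O)(=O)N4CCN(c5ccccc5)C(C)C4)cc3)[nH]c2c1=O`: > 1000 nM, a limit of the assay.

No number is known for compound 2 in this assay, only a limit. The same holds for the other two, as the limit of > 1000 nM in this assay, at which 3 of the 3 values shown sit, shows. Compound 4 `CCCn1c(=O)[nH]c2nc(-c3ccc(S(=O)(=O)N4CCN(Cc5cccc(C)c5)CC4)cc3)[nH]c2c1=O` carries the change (3-methylbenzyl in place of 4-bromophenyl on an amine nitrogen in a ring). Going by the values given here, no step between measured compounds is available, so the size of the change cannot be read from neighbours. The three limits suggest that compound 4 is expected to stay near the same limit, with the step from compound 2 to compound 4 estimated as a step that the limit leaves unreadable from compound 2 to compound 4. For compound 4 the expected inhibition constant is 2500 nM, within 400 nM to 15000 nM.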

Compound 4, inhibition constant: > 1000 nM
Compound 4: a limit, no number (the forecaster's own chance of this, stated with the estimate: 70%); the middle value is on the limit's open side.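

No step can be read from compound 2 to compound 4, since each gives only a limit and not a number: the limit of > 1000 nM in this assay, at which 4 of the 4 values shown sit.

The compounds shown leave open how strong an inhibitor each one is in this assay, and so whether 3-methylbenzyl or 4-bromophenyl gives the stronger inhibitor.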